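The source may report more compounds than this note shows. Statements on the series, on what has been measured and on what is new or still open speak of the compounds shown alone.

Measured compounds:

Compound 1 `COc1ccccc1C(=O)Nc1nc(Cl)ncc1Sc1ccc([N+](=O)[O-])cc1` gives 480000 nM in an ADME assay on H9 cells (Homo sapiens) for cytotoxicity, read by MTT assay, with a stated time of 7 days; on this read-out lower numbers stand for higher toxicity in this test and higher numbers for lower toxicity in this test.
Compound 2 `COc1ccccc1NC(=O)c1cccnc1Sc1ccc([N+](=O)[O-])cc1` gives 525000 nM in this assay.
Compound 3 `COc1ccccc1NC(=O)c1cc(N)ccc1Sc1ccc([N+](=O)[O-])cc1` gives 506000 nM in this assay.

The three numbers sit close together. Compound 3 holds the second highest of them, with compound 2 nearest and compound 1 furthest, both gaps within the usual scatter, so the three cannot be told apart on this read-out.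

Compound 4 `COc1ccccc1NC(=O)c1cc(NC(C)=O)ccc1Sc1ccc([N+](=O)[O-])cc1` has not yet been tested. It differs from compound 3 in one place: acetyl in place of hydrogen on a nitrogen on an aromatic ring.

Within the data shown here, nothing among the measured compounds speaks to such a change, and the three numbers already agree with each other; the expected step is therefore a 1.0-fold lower number from compound 3 to compound 4 (0.01 log units; within the scatter), none beyond the scatter. Compound 4 is estimated at 500000 nM, in the range from 250000 nM to 1000000 nM.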

Compound 4, half-maximal cytotoxic concentration: 171000 nM
Compound 4: the middle estimate sits 2.9-fold (0.47 log units) above what was measured; the whole stated range lies above it.
By their numbers in this assay, from the lowest: compound 4; then compounds 1, 3 and 2 (each within the scatter of the next).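

Acetyl in place of hydrogen on this nitrogen, amino to acetamido, gives a 3.0-fold lower number from compound 3 to compound 4 (0.47 log units; beyond the scatter) in this assay and so marks higher toxicity in this test. Among these compounds, the earlier compounds, all within the scatter of each other, showed no step of any kind, so this nitrogen is the first place seen to respond, though modestly. Nothing measured here bears on why the number moves.

From the compounds shown here alone, whether a propionyl, a methanesulfonyl or a simple methyl on the same nitrogen would move the number likewise stays open. So does whether the step carries over to the cores of compound 1 and compound 2.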